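Volume of distribution in a paired-stereochemistry amide series

The source may report more compounds than this note shows. Statements on the series, on what has been measured and on what is new or still open speak of the compounds shown alone.

Measured compounds:
compound 1 `COC(=O)N[C@H](C(=O)N1CCC[C@H]1C(=O)Nc1ccc([C@H]2CC[C@H](c3ccc(NC(=O)[C@@H]4CCCN4C(=O)[C@@H](NC(=O)OC)C(C)C)cc3)N2c2ccc(C(F)(F)F)cc2)cc1)C(C)C`: 1.3 L/kg
compound 2 `COC(=O)N[C@H](C(=O)N1CCC[C@H]1C(=O)Nc1ccc([C@@H]2CC[C@@H](c3ccc(NC(=O)[C@@H]4CCCN4C(=O)[C@@H](NC(=O)OC)C(C)C)cc3)N2c2ccc(C(F)(F)F)cc2)cc1)C(C)C`: 8.9 L/kg
compound 3 `COC(=O)N[C@H](C(=O)N1CCC[C@H]1C(=O)Nc1ccc([C@@H]2CC[C@@H](c3ccc(NC(=O)[C@@H]4CCCN4C(=O)[C@@H](NC(=O)OC)[C@H]4CCOC4)cc3)N2c2ccc(F)cc2)cc1)[C@H]1CCOC1`: 0.5 L/kg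

In an ADME assay on the whole organism for pharmacokinetics, with Rattus norvegicus as the target, at a dose of 3 mg/kg by the intravenous route (on this read-out higher numbers stand for wider distribution into tissues and lower numbers for narrower distribution), compound 1 stands second highest of the three numbers: compound 2 lies furthest from it, and compound 3 is the nearest. Within the data shown here, the only measured step is a 6.8-fold higher number from compound 1 to compound 2 (0.84 log units; beyond the scatter), which rests on the fact that compounds 1 and 2 differ only in the configuration as drawn and involves no change of substituent. Compound 4 `COC(=O)N[C@H](C(=O)N1CCC[C@H]1C(=O)Nc1ccc([C@H]2CC[C@H](c3ccc(NC(=O)[C@@H]4CCCN4C(=O)[C@@H](NC(=O)OC)C(C)C)cc3)N2c2ccc(F)cc2)cc1)C(C)C` differs from compound 1 by fluoro in place of trifluoromethyl on an aromatic carbon. Among the measured compounds shown here, no measured step covers this change; compound 3 carries the fluorophenyl but differs elsewhere too, so its value only gives a loose lower reference. A small step, within or near the scatter, is expected, a 1.4-fold lower number from compound 1 to compound 4 (0.16 log units; within the scatter). Compound 4 is estimated at 0.9 L/kg, between 0.4 L/kg and 2 L/kg.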

Compound 4, volume of distribution at steady state in the Rattus norvegicus assay: 0.5 L/kg
For compound 4 the middle estimate is 1.8-fold (0.26 log units) above the measured one, within the range that was stated.
By their numbers in the Rattus norvegicus assay, from the lowest: compounds 3 and 4 (each within the scatter of the next); then compound 1; then compound 2.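

In the Rattus norvegicus assay fluoro in place of trifluoromethyl on an aromatic carbon gives a 2.6-fold lower number from compound 1 to compound 4 (0.41 log units; beyond the scatter) and so shows that this aromatic position, and not configuration alone, moves the read-out. In a physicochemical assay for lipophilicity, read by HPLC, at pH 7.4 (a lower number here means a more polar compound, a higher number a more lipophilic compound), compound 1 gives 4.9 and compound 4 gives 4.6 with the two values within the scatter of each other. Nothing at hand bears on the cause of the step in tissue distribution.

Open, from the compounds shown here alone, is whether the same change gives a step of like size in the configuration of compound 2. Also open, going by these compounds, is how a nitrile, a methoxy group or an amine at this aromatic carbon would stand in the Rattus norvegicus assay against fluoro and trifluoromethyl.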